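Chloro to fluoro on the pendant phenyl: compound 4 outlook

The source may report more compounds than this note shows. Statements on the series, on what has been measured and on what is new or still open speak of the compounds shown alone.

Among the compounds with values here, compound 2 `O=S(=O)(c1ccc(F)c(F)c1)c1cnc2cc(F)ccc2c1-c1cccc(Cl)c1` gives 0.38 mL/min in an ADME assay on microsomes from liver (Homo sapiens) for metabolic stability, tested at 2.5 uM (a higher number here means faster removal of the compound, a lower number slower removal), the second highest of the three numbers so far. Compound 1 `O=S(=O)(c1cc(F)cc(F)c1)c1cnc2cc(F)ccc2c1-c1cccc(Cl)c1` gives 0.22 mL/min in this assay, and compound 3 `O=S(=O)(c1cc(Cl)cc(Cl)c1)c1cnc2cc(F)ccc2c1-c1cccc(Cl)c1` gives 0.93 mL/min. All three measured steps sit on the sulfonyl sulfur: a 1.7-fold higher number from compound 1 to compound 2 (0.24 log units; within the scatter), a 4.2-fold higher number from compound 1 to compound 3 (0.63 log units; beyond the scatter) and a 2.4-fold higher number from compound 2 to compound 3 (0.39 log units; beyond the scatter). Compound 4 `O=S(=O)(c1ccc(F)c(F)c1)c1cnc2cc(F)ccc2c1-c1cccc(F)c1` differs from compound 2 elsewhere: fluoro in place of chloro on an aromatic carbon. Within the data shown here, no measured step touches that aromatic carbon, so none bears on this change directly; the measured steps only show that the series so far stays within a narrow band. The step is therefore expected to be a 1.3-fold lower number from compound 2 to compound 4 (0.10 log units; within the scatter), not beyond the scatter. Compound 4 is expected to give 0.3 mL/min in this assay, within a range from 0.14 mL/min to 0.65 mL/min.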

Compound 4, intrinsic clearance in a liver preparation (reported as CLH), per the amount of preparation that the assay uses: 0.6 mL/min
The estimate for compound 4 lay 2.0-fold (0.30 log units) below the measured number, and the stated range covers the measured number.
By their numbers in this assay, from the lowest: compounds 1, 2, 4 and 3 (each within the scatter of the next, the first and the last beyond it).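

The 3-chlorophenyl to 3-fluorophenyl change gives a 1.6-fold higher number from compound 2 to compound 4 (0.20 log units; within the scatter) in this assay. Within the data shown here, this is the first reading at this aromatic carbon, which lies away from the sulfonyl sulfur, and this halogen swap stays within the scatter, unlike the dichloro step on the sulfonyl side. Nothing available bears on the reason for this result.

From the compounds shown here alone, whether the swap behaves the same way alongside the other sulfonyl aryl groups remains open. So does the outcome at this carbon with methoxy, an amine or a carboxylic acid.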